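Swapping the pyridine for a triazole at the far end

The source may report more compounds than this note shows. Statements on the series, on what has been measured and on what is new or still open speak of the compounds shown alone.

In a functional assay on HEK293 cells for agonist activity at Bombesin receptor subtype-3 (Homo sapiens), read by luminescence and calcium flux, with a stated time of 10 min (a higher number here means that more compound is needed for the effect, a lower number that less compound is needed), compound 3 `CCC(C)(C)Cc1c[nH]c(CCc2ccc(-c3cccnc3)cc2)n1` gives 131 nM, the lowest of the three numbers measured. Compound 1 `CCC(C)(C)Cc1c[nH]c(CCc2ccc(-c3ccncc3)cc2)n1` gives 305 nM in this assay, and compound 2 `c1ccc(-c2ccc(CCc3nc(CC4CCCC4)c[nH]3)cc2)nc1` gives 425 nM. Within the data shown here, the only measured step between a matched pair is a 2.3-fold lower number from compound 1 to compound 3 (0.37 log units; beyond the scatter), a shift of one nitrogen within a six-membered ring. Compound 4 `CCC(C)(C)Cc1c[nH]c(CCc2ccc(-n3ccnn3)cc2)n1` differs from compound 3 by 1H-1,2,3-triazol-1-yl in place of pyridin-3-yl on an aromatic carbon. Among the measured compounds shown here, no measured step involves a five-membered ring, so that modest step is the only guide, and it does not cover a change of ring size. A step in either direction of similar size seems plausible, with a slightly higher number more likely. Compound 4 is expected near 300 nM, between 100 nM and 1000 nM, which is an expected step of a 2.3-fold higher number from compound 3 to compound 4 (0.36 log units; beyond the scatter).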

Compound 4, half-maximal effective concentration: 641 nM
The estimate for compound 4 lay 2.1-fold (0.33 log units) below the measured number; the range from low to high includes it.
By their numbers in this assay, from the lowest: compound 3; then compounds 1, 2 and 4 (each within the scatter of the next, the first and the last beyond it).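

In this assay, putting 1H-1,2,3-triazol-1-yl in place of either pyridine raises the number, with a 4.9-fold higher number from compound 3 to compound 4 (0.69 log units; beyond the scatter) and a 2.1-fold higher number from compound 1 to compound 4 (0.32 log units; beyond the scatter), so at this position the five-membered ring needs more compound than both six-membered rings. The larger step is the one away from pyridin-3-yl. Nothing available here explains why the number rises.

Still open, as far as these compounds go, is how a plain phenyl ring or an amine would behave on this aromatic carbon. Also open, from the compounds shown here alone, is whether the triazole would give a similar step on the core of compound 2.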